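A few compounds are considered here, and "the series" means these few. Any claim that something is new, unique, unknown or untested is made for them only; others in the source may bear on it.

Measured in an ADME assay on Vero cells (Chlorocebus sabaeus) for cytotoxicity, read by resazurin assay, with a stated time of 3 days; a higher number here means a weaker inhibitor, a lower number a stronger inhibitor:
compound 1 `CCOCCOC(=O)Nc1cc2nc(C3CCCCC3)[nH]c2cc1N(C)C`: > 100 ug/mL
compound 2 `O=C(CCc1ccccc1)Nc1cc2nc(C3CCCCC3)[nH]c2cc1N1CCCC1`: > 100 ug/mL

Neither entry is a number. Compound 2 stands at the limit of > 100 ug/mL in this assay, at which 2 of the 2 values shown sit, so only a limit is known for it. Compound 3 `CCOCCOC(=O)Nc1cc2nc(C3CCCCC3)[nH]c2cc1N1CCCC1` has 2-ethoxyethoxy in place of phenethyl on a carbonyl carbon. Compound 1 carries the same 2-ethoxyethoxy group, and its > 100 ug/mL is also a limit. For the measured compounds named here, no measured step exists in this assay, and no change beyond the scatter is expected, in either direction. The expected size is a number no higher from compound 2 to compound 3 (the limit leaves the size open). The estimate for compound 3 is 100 ug/mL, with an expected range of 40 ug/mL to 200 ug/mL.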

Compound 3, half-maximal inhibitory concentration: > 100 ug/mL
Compound 3 ended at the assay's limit (the forecaster's own chance of this, stated with the estimate: 80%); the middle value lies on the limit itself.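

No new step can be read from compound 3 to compound 2 or compound 1, because all three entries are limits: the limit of > 100 ug/mL in this assay, at which 3 of the 3 values shown sit.

The compounds shown leave open the actual values of compound 1, compound 2 and compound 3 in this assay, and so whether either group change has any effect.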